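The source may report more compounds than this note shows. Statements on the series, on what has been measured and on what is new or still open speak of the compounds shown alone.

The measured compounds:
Compound 1, `Cc1cc2[nH]nc(N)c2c(N2CCCCC2)n1`: in an assay on isolated protein for inhibition of ribosomal protein S6 kinase alpha-1 (Homo sapiens), read by mobility shift assay, tested at 30 uM (a higher number here means more inhibition at the concentration tested (going by the name of the read-out), a lower number less inhibition), compound 1 gives 46%.
Compound 2, `CC(=O)Nc1nn(C)c2cc(-c3ccccc3)[nH]c(=O)c12`: compound 2 gives 4%.
Compound 3, `Cc1cc2c(c(N)nn2C)c(N2CCCCC2)n1`: compound 3 gives 23%.

Among these three numbers compound 3 stands second highest. Its nearest neighbour is compound 2, whose value lies below it by a gap beyond the scatter, and the furthest is compound 1, which lies above it, again beyond the scatter. The one measured step that links two of these compounds runs a number 23 percentage points lower from compound 1 to compound 3 (beyond the scatter), the change being methyl in place of hydrogen on an aromatic nitrogen.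

Compound 4, `Cc1cc2c(c(N)nn2C)c(N2CC[C@H](O)C2)n1`, has not yet been measured in this assay. It differs from compound 3 in one place: 3-hydroxypyrrolidin-1-yl in place of piperidin-1-yl on an aromatic carbon. Among the measured compounds shown here, no measured pair shows this exchange or anything near it. For the measured compounds named here, the step from compound 1 to compound 3 concerns a different position and a different kind of change, and compound 2 shares neither the core of compound 3 nor the ring being exchanged, so none of the measured steps bears on the change. Without such a precedent there is no ground for a step beyond the scatter in either direction, and the expected step is a number 5 percentage points lower from compound 3 to compound 4 (within the scatter). Compound 4 is therefore estimated at 18%, with a range from 0% to 40%.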

Compound 4, a percentage reported as inhibition, at one concentration (the size of the read-out at that concentration, not a potency): -5%
Compound 4: the middle estimate sits 23 percentage points above what was measured, outside the stated range (below it).
By their numbers in this assay, from the lowest: compounds 4 and 2 (each within the scatter of the next); then compound 3; then compound 1.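

In this assay, among the compounds shown here, exchanging piperidin-1-yl for 3-hydroxypyrrolidin-1-yl on the aromatic carbon next to the ring nitrogen gives a number 28 percentage points lower from compound 3 to compound 4 (beyond the scatter), so this position, which no earlier pair had touched, does respond to what it carries. The earlier step showed only what a methyl on an aromatic nitrogen does, and it still left compound 3 at 23%, whereas this exchange leaves compound 4 at -5%, with no inhibition to read at the concentration tested. The exchange replaces a six-membered ring with a five-membered one and brings in a hydroxy group in the same step, and nothing measured here explains the drop.

The compounds shown cannot say whether the ring size or the hydroxy group carries the step, a question that plain pyrrolidin-1-yl and 4-hydroxypiperidin-1-yl would separate. Also open, going by these compounds, are how the opposite enantiomer of the 3-hydroxypyrrolidin-1-yl group, or a morpholin-4-yl group, would read at this position, and whether the same exchange would cost as much on the core of compound 1.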